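A 4-Methylphenyl Swap on the Shared Core

The compounds below may be only part of what the source reports. "The series", "measured", "known", "first", "only" and "open" are said of these compounds alone.

In a functional assay, read by Griess assay, with a stated time of 2.5 h (a lower number here means a stronger inhibitor, a higher number a weaker inhibitor), compound 1 (`COc1cc(OC)c(OC)cc1/C=C/C(=O)c1ccc(-c2c[nH]cn2)cc1`) gives 1.97 ug/mL and compound 2 (`COc1cc(OC)c(OC)cc1/C=C/C(=O)c1cc(Cl)ccc1O`) gives 2.32 ug/mL so the two values lie within the usual scatter of each other. Compound 3 (`COc1cc(OC)c(OC)cc1/C=C/C(=O)c1ccc(C)cc1`) awaits measurement and carries 4-methylphenyl in place of 5-chloro-2-hydroxyphenyl on a carbonyl carbon. Among the measured compounds shown here, no measured step isolates this change, so no shift beyond the scatter is expected in this assay although this expectation remains uncertain. The expected change is a 1.1-fold higher number from compound 2 to compound 3 (0.03 log units; within the scatter) and stays within the scatter. Compound 3 is estimated at 2.5 ug/mL (expected range 1 ug/mL to 6 ug/mL).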

Compound 3, half-maximal inhibitory concentration: 2.18 ug/mL
Compound 3: the middle estimate sits 1.1-fold (0.06 log units) above what was measured; the range from low to high includes it.
By their numbers in this assay, from the lowest: compounds 1, 3 and 2 (each within the scatter of the next).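

In this assay, 4-methylphenyl in place of 5-chloro-2-hydroxyphenyl on a carbonyl carbon gives a 1.1-fold lower number from compound 2 to compound 3 (0.03 log units; within the scatter) and stays within the scatter, while methyl in place of 1H-imidazol-4-yl on an aromatic carbon gives a 1.1-fold higher number from compound 1 to compound 3 (0.04 log units; within the scatter) and also stays within the scatter. Among these three compounds, this position therefore carries a group with no hydrogen-bond donor or acceptor without any shift beyond the scatter. No supporting evidence bears on this result.

On these data alone, whether an amine or a carboxylic acid at this position would stay within the scatter remains open. So does whether a longer chain in place of the methyl would.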